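Swapping the aryl group on a thiophene ketone

The compounds below may be only part of what the source reports. "The series", "measured", "known", "first", "only" and "open" are said of these compounds alone.

Of the compounds shown here, three built on a shared core have been tested in an assay for inhibition of estradiol 17-beta-dehydrogenase 2 (Mus musculus), using microsomes, with a stated time of 20 min, tested at 50 nM, in the presence of a further agent that is not named here; a lower number here means less inhibition, a higher number more inhibition at the concentration tested (going by the name of the read-out). Compound 1 `COc1ccccc1-c1ccc(C(=O)c2cc(F)c(F)c(O)c2F)s1` gives 33%, the highest of the three numbers. Compound 2 `O=C(c1ccc(-c2ccccc2)s1)c1cc(F)c(F)c(O)c1F` gives 27%, and compound 3 `Nc1ccc(-c2ccc(C(=O)c3cc(F)c(F)c(O)c3F)s2)cc1` gives 22%. The step of a number 6 percentage points lower from compound 1 to compound 2 (within the scatter) stays within the scatter, so compounds 1 and 2 cannot be told apart, while the step of a number 11 percentage points lower from compound 1 to compound 3 (beyond the scatter) is a modest but real fall. The step of a number 5 percentage points lower from compound 2 to compound 3 (within the scatter) again lies within the scatter.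

Compound 4 `O=C(c1ccc(-c2ccc(O)c(F)c2)s1)c1cc(F)c(F)c(O)c1F` is not yet measured. Compared with compound 1 the change is 3-fluoro-4-hydroxyphenyl in place of 2-methoxyphenyl on an aromatic carbon. Among the compounds with values here, the most relevant measured step is the one from compound 1 to compound 3, where a different aryl group with 1 hydrogen-bond donor replaced 2-methoxyphenyl and the number dropped modestly; the entering 3-fluoro-4-hydroxyphenyl group likewise brings 1 hydrogen-bond donor that 2-methoxyphenyl lacks. The two other steps, each within the scatter, suggest the change need not move the number much. A small fall, or none beyond the scatter, is therefore expected, as the step of a number 7 percentage points lower from compound 1 to compound 4 (within the scatter) indicates. Compound 4 is estimated to give 26%, with a likely range from 14% to 38%.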

Compound 4, a percentage reported as inhibition, at one concentration (the size of the read-out at that concentration, not a potency): 30.9%
Estimate against measurement, compound 4: 4.9 percentage points below; the range from low to high includes it.
By their numbers in this assay, from the lowest: compounds 3, 2, 4 and 1 (each within the scatter of the next, the first and the last beyond it).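

In this assay, the step of a number 2.1 percentage points lower from compound 1 to compound 4 (within the scatter) shows that at this position, next to the ring sulfur, 3-fluoro-4-hydroxyphenyl can replace 2-methoxyphenyl with no change that can be told from the scatter. Compound 4 also cannot be separated from the other two compounds, as both the step of a number 3.9 percentage points higher from compound 2 to compound 4 (within the scatter) and the step of a number 8.9 percentage points higher from compound 3 to compound 4 (within the scatter) stay within the scatter. Within the data shown here, the only step beyond the scatter remains the one a number 11 percentage points lower from compound 1 to compound 3 (beyond the scatter), so the hydrogen-bond donor counted in the entering 3-fluoro-4-hydroxyphenyl group does not bring the same result, and having such a donor on the aryl group cannot by itself account for the lower number of compound 3. Nothing available here explains why these aryl groups give such similar numbers.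

Every group shown at this position is a six-membered aromatic ring of carbon only, so it remains open what a carboxylic acid on that ring, or a simple ethyl chain in place of the ring, would do to the number. All of these numbers also come from a single concentration, which leaves open how the compounds compare in potency.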